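This account rests on a few compounds, and the source may have more. Where it says the series, first, only, none or still open, it means among the compounds named here.

Compound 1 `COC(=O)N[C@H](C(=O)N1CCC[C@H]1C(=O)Nc1ccc([C@H]2CC[C@H](c3ccc(NC(=O)[C@@H]4CCCN4C(=O)[C@@H](NC(=O)OC)C(C)C)cc3)N2c2ccc(C(F)(F)F)cc2)cc1)C(C)C`: 4.9. Compound 2 `COC(=O)N[C@H](C(=O)N1CCC[C@H]1C(=O)Nc1ccc([C@@H]2CC[C@@H](c3ccc(NC(=O)[C@@H]4CCCN4C(=O)[C@@H](NC(=O)OC)C(C)C)cc3)N2c2ccc(F)cc2)cc1)C(C)C`: 4.6.

In a physicochemical assay for lipophilicity, read by HPLC, at pH 7.4 (on this read-out lower numbers stand for lower lipophilicity and higher numbers for higher lipophilicity), compound 2 gives 4.6, while compound 1 gives 4.9; the two numbers lie within the usual scatter of each other, so neither can be placed above the other. Compound 3 `COC(=O)N[C@H](C(=O)N1CCC[C@H]1C(=O)Nc1ccc([C@H]2CC[C@H](c3ccc(NC(=O)[C@@H]4CCCN4C(=O)[C@@H](NC(=O)OC)C(C)C)cc3)N2c2ccc(F)cc2)cc1)C(C)C` is not yet measured. It differs from compound 2 as follows: the two compounds have the same atoms and bonds and differ only in configuration as drawn: 2 of 6 stereo elements differ; a stereocentre at a saturated ring carbon is drawn S in compound 2 and R in compound 3; a stereocentre at a saturated ring carbon is drawn S in compound 2 and R in compound 3. Among the compounds with values here, no measured pair in this set separates two such configurations, so nothing here fixes the size of such a step. Compound 3 is expected to show no step beyond the scatter, the estimated step being no change at the digits printed from compound 2 to compound 3 (within the scatter). Compound 3 is therefore estimated at 4.6, expected between 4.3 and 4.9.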

Compound 3, distribution coefficient: 4.6
Estimate against measurement, compound 3: no gap at the digits printed, and the stated range covers the measured number.
By their numbers in this assay, from the lowest: compounds 2, 3 and 1 (each within the scatter of the next).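

In this assay, within the data shown here, redrawing two stereocentres at saturated ring carbons from S to R gives no change at the digits printed from compound 2 to compound 3 (within the scatter), the only pair here that separates such configurations. Among these compounds, compound 3 also gives the only pair differing at the aromatic substituent: fluoro in place of trifluoromethyl on an aromatic carbon gives a number 0.30 log units lower from compound 1 to compound 3 (within the scatter). The stereocentre step speaks to configuration alone, on this ground: the fact that compounds 2 and 3 differ only in the configuration as drawn.

The compounds shown leave open whether a nitrile or a methoxy group on that aromatic carbon would read beyond the scatter. They also leave open how the S and R configurations compare with trifluoromethyl in place of fluoro.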